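This account rests on a few compounds, and the source may have more. Where it says the series, first, only, none or still open, it means among the compounds named here.

Measured so far:

Compound 1 `Cc1ccc(CSc2cc(Cl)c(C)cc2S(=O)(=O)/N=C(\N)n2nc(C)cc2-c2ccccc2)cc1` gives 89000 nM in a functional assay on MCF7 cells (Homo sapiens) for cytotoxicity, read by MTT assay, with a stated time of 72 h; on this read-out lower numbers stand for stronger inhibition and higher numbers for weaker inhibition.
Compound 2 `Cc1cc(S(=O)(=O)/N=C(\N)n2nccc2-c2ccccc2)c(SCc2cccc(Cl)c2)cc1Cl` gives 88000 nM in this assay.
Compound 3 `Cc1cc(S(=O)(=O)/N=C(\N)n2nccc2-c2ccccc2)c(SCc2cccc3ccccc23)cc1Cl` gives 58000 nM in this assay.

Compound 3 has the lowest of the three numbers, but its gaps to compound 2 and to compound 1 both lie within the usual scatter, so none of the three can be called stronger or weaker than another. The change from compound 3 to compound 4 `Cc1ccc(CSc2cc(Cl)c(C)cc2S(=O)(=O)/N=C(\N)n2nccc2-c2ccccc2)cc1` is 4-methylphenyl in place of naphthalen-1-yl on a saturated chain carbon bound to a sulfur. Within the data shown here, the one measured step at this same place, a 1.5-fold lower number from compound 2 to compound 3 (0.18 log units; within the scatter), was itself within the scatter, which suggests that swapping the aromatic group on that chain carbon moves the number little. Compound 1, which also carries 4-methylphenyl at that place, gives 89000 nM, again close to the others. Compound 4 is therefore expected to give a number near those already seen, with the step of a 1.4-fold higher number from compound 3 to compound 4 (0.14 log units; within the scatter) expected to stay within the scatter. The estimate for compound 4 in this assay is 80000 nM, with a likely range from 40000 nM to 160000 nM.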

Compound 4, half-maximal inhibitory concentration: 21000 nM
Compound 4: middle estimate off by 3.8-fold (0.58 log units), on the high side; measured number below the stated range.
By their numbers in this assay, from the lowest: compound 4; then compounds 3, 2 and 1 (each within the scatter of the next).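

In this assay the group on a saturated chain carbon bound to a sulfur turns out to matter: 4-methylphenyl in place of naphthalen-1-yl gives a 2.8-fold lower number from compound 3 to compound 4 (0.44 log units; beyond the scatter) and 4-methylphenyl in place of 3-chlorophenyl gives a 4.2-fold lower number from compound 2 to compound 4 (0.62 log units; beyond the scatter) while naphthalen-1-yl in place of 3-chlorophenyl gave only a 1.5-fold lower number from compound 2 to compound 3 (0.18 log units; within the scatter) in the earlier comparison. A second place counts as well: compound 1 also carries 4-methylphenyl, yet hydrogen in place of methyl on an aromatic carbon gives a 4.2-fold lower number from compound 1 to compound 4 (0.63 log units; beyond the scatter) with that group unchanged. All three new steps are modest, and compound 4 still gives 21000 nM in this assay as its number.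

On these data alone, it stays open how plain phenyl, cyclohexyl or a 4-aminophenyl group would behave on that chain carbon, and how an ethyl group or an amine would compare with hydrogen and methyl on the aromatic carbon. Nothing measured here explains these steps.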